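This account rests on a few compounds, and the source may have more. Where it says the series, first, only, none or still open, it means among the compounds named here.

In a functional assay on MCF7 cells (Homo sapiens) for cytotoxicity, read by MTT assay, with a stated time of 72 h (on this read-out lower numbers stand for stronger inhibition and higher numbers for weaker inhibition), compound 1 `O=C1c2c[n+]([O-])c3ccccc3c2C(=O)c2c1c1ccccc1n2CCCCn1ccnc1` gives 130 nM, while compound 2 `CCCN1CCN(CCCCn2c3c(c4ccccc42)C(=O)c2c[n+]([O-])c4ccccc4c2C3=O)CC1` gives 1280 nM, the higher of the two numbers and so the weaker result. Compound 3 `O=C1c2c[n+]([O-])c3ccccc3c2C(=O)c2c1c1ccccc1n2CCCN1CCC(O)CC1` has not yet been measured. Its difference from compound 2 is 4-hydroxypiperidin-1-yl in place of (4-propylpiperazin-1-yl)methyl on a saturated chain carbon, three bonds along the chain from an aromatic nitrogen. In words, 4-hydroxypiperidin-1-yl stands in place of (4-propylpiperazin-1-yl)methyl on a saturated chain carbon, three bonds along the chain from an aromatic nitrogen. Within the data shown here, only one measured step bears on this change, a swap of the group on the chain: a 9.8-fold higher number from compound 1 to compound 2 (0.99 log units; beyond the scatter). Among the measured compounds shown here, this modest step lies beyond the scatter, but no measured compound carries 4-hydroxypiperidin-1-yl, so it offers only a rough guide to size. In this assay, a smaller step towards a lower number is expected: a 2.6-fold lower number from compound 2 to compound 3 (0.41 log units; beyond the scatter). The estimated value for compound 3 is 500 nM, with a range from 130 nM to 1800 nM.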

Compound 3, half-maximal inhibitory concentration: 190 nM
Compound 3: middle estimate off by 2.6-fold (0.42 log units), on the high side, within the range that was stated.
By their numbers in this assay, from the lowest: compounds 1 and 3 (each within the scatter of the next); then compound 2.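

In this assay, the change from the propylpiperazine side chain to the hydroxypiperidine side chain gives a 6.7-fold lower number from compound 2 to compound 3 (0.83 log units; beyond the scatter), so a saturated six-membered ring on the chain does not by itself bring the weaker number of compound 2. Replacing the imidazole side chain gives a 1.5-fold higher number from compound 1 to compound 3 (0.16 log units; within the scatter), which shows that the 1H-imidazol-1-yl group of compound 1 is not needed for a number in this range, and the two compounds cannot be ordered. On these data alone, both steps alter the ring and the chain together, as 3-(4-propylpiperazin-1-yl)propyl becomes 2-(4-hydroxypiperidin-1-yl)ethyl, so their separate shares stay unknown.

As far as these compounds go, whether 4-hydroxypiperidin-1-yl on the longer chain, a piperidine without the hydroxyl, or a morpholine would give a similar number remains open. Nothing available explains why these side chains differ.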